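A few compounds are considered here, and "the series" means these few. Any claim that something is new, unique, unknown or untested is made for them only; others in the source may bear on it.

Compound 1 `CC1=CC[C@H](C(C)(C)NC(=S)N/N=C/c2ccc(O)cc2)CC1`: in an ADME assay on Vero cells (Chlorocebus sabaeus) for inhibition, read by sulforhodamine B assay, with a stated time of 48 h (a lower number here means a stronger inhibitor of growth, a higher number a weaker inhibitor of growth), compound 1 gives > 100000 nM, which is a limit of the assay and not a number.
Compound 2 `CC1=CC[C@H](C(C)(C)NC(=S)N/N=C/c2cccc(Cl)c2)CC1`: in this assay compound 2 gives > 100000 nM, again a limit of the assay rather than a measured number.

Compound 2 therefore stands at the limit of > 100000 nM in this assay, at which 2 of the 2 values shown sit, and nothing finer than that can be read off for it. For the measured compounds named here, the one measured step, a step that the two limits leave unreadable from compound 1 to compound 2, is a change of the aromatic group hanging on the carbon with a double bond to nitrogen; the two limits hide whether that swap shifted growth inhibition at all.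

Compound 3 `CC1=CC[C@H](C(C)(C)NC(=S)N/N=C/c2ccco2)CC1` differs from compound 2 by furan-2-yl in place of 3-chlorophenyl on a carbon with a double bond to nitrogen. Going by the values given here, the only measured step bears on the same position but gives no readable size, so there is no measured basis for expecting a step beyond the scatter in this assay in either direction. Compound 3 is expected to give about 150000 nM in this assay, within a range from 50000 nM to 500000 nM, most likely again reported only as a limit. The step that the limit leaves unreadable from compound 2 to compound 3 is thus estimated to be small.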

Compound 3, concentration for total growth inhibition: 14700 nM
The estimate for compound 3 lay 10-fold (1.01 log units) above the measured number; measured number below the stated range.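

The group on the carbon with a double bond to nitrogen can change the result in this assay, which the first two compounds could not show. Replacing 3-chlorophenyl with furan-2-yl gives an at least 6.8-fold lower number from compound 2 to compound 3 (0.83 log units; beyond the scatter), and replacing 4-hydroxyphenyl with the same group gives an at least 6.8-fold lower number from compound 1 to compound 3 (0.83 log units; beyond the scatter), so in both cases the furan-2-yl compound is the stronger inhibitor of growth. Both steps start from a limit rather than a number, so they give only a minimum size, and compound 3 is the only one of the three with a measured number, while the two compounds with a six-membered aromatic ring of carbon only stay at the limit: the limit of > 100000 nM in this assay, at which 2 of the 3 values shown sit.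

The furan-2-yl swap changes ring size and brings in an oxygen at the same time, so the compounds shown cannot separate these two changes. A thiophen-2-yl group, with sulfur in place of the oxygen, and a pyridin-2-yl group, with a ring nitrogen in a six-membered ring, could help show whether the ring size, the hetero atom or both go with the lower number.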